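Swapping the Aryl Group on the Chain in Compound 3

The source may report more compounds than this note shows. Statements on the series, on what has been measured and on what is new or still open speak of the compounds shown alone.

Two measured compounds share one core and differ only in the aryl group sitting on a double-bonded chain carbon bound to a double-bonded chain carbon. Compound 1 `COc1ccc(C(=O)c2cc(OC)c(OC)c(OC)c2)cc1NC(=O)/C=C/c1cc(OC)c(OC)c(OC)c1` carries a 3,4,5-trimethoxyphenyl there, and in a functional assay on HT-29 cells (Homo sapiens) for cytotoxicity, read by MTT assay, with a stated time of 72 h (on this read-out lower numbers stand for stronger inhibition and higher numbers for weaker inhibition), compound 1 gives 3100 nM. Among the measured compounds shown here, compound 2 `COc1ccc(C(=O)c2cc(OC)c(OC)c(OC)c2)cc1NC(=O)/C=C/c1ccc(C(F)(F)F)cc1` carries a 4-(trifluoromethyl)phenyl instead; in this assay compound 2 gives 1600 nM, the lowest of the two numbers so far, with compound 1 the nearest neighbour. That single step at this position was a 1.9-fold lower number from compound 1 to compound 2 (0.29 log units; within the scatter), so changing the aryl group here has so far moved the number little. Compound 3 `COc1ccc(C(=O)c2cc(OC)c(OC)c(OC)c2)cc1NC(=O)/C=C/c1cccc(OC(F)(F)F)c1` changes the same group again: 3-(trifluoromethoxy)phenyl in place of 4-(trifluoromethyl)phenyl on a double-bonded chain carbon bound to a double-bonded chain carbon. For the measured compounds named here, no measured step involves a trifluoromethoxy group, so only the size of the earlier step guides the expectation. The step from compound 2 to compound 3 is expected to be a 1.1-fold higher number from compound 2 to compound 3 (0.05 log units; within the scatter), not clearly beyond the scatter. The estimate for compound 3 in this assay is 1800 nM, ranging from 700 nM to 5000 nM.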

Compound 3, half-maximal inhibitory concentration: 5200 nM
Beside the measured number, compound 3's estimate is 2.9-fold (0.46 log units) below it, outside the stated range (above it).
By their numbers in this assay, from the lowest: compounds 2, 1 and 3 (each within the scatter of the next, the first and the last beyond it).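

In this assay, among the compounds shown here, the swap gives a 3.3-fold higher number from compound 2 to compound 3 (0.51 log units; beyond the scatter) and is the first change of the aryl group on the chain to pass beyond the scatter, so this position can move the number, though only modestly. The swap from the 3,4,5-trimethoxyphenyl gives a 1.7-fold higher number from compound 1 to compound 3 (0.22 log units; within the scatter) and stays within the scatter, so compound 1 and compound 3 cannot be told apart here. Nothing available explains why the number shifted.

The step from compound 2 to compound 3 changes two things at once, the trifluoromethyl becoming a trifluoromethoxy and the group's number going from 4 to 3, and the compounds shown cannot say which of these matters; a 4-(trifluoromethoxy)phenyl or a 3-(trifluoromethyl)phenyl would separate them. Also open, as far as these compounds go, is how the number responds to an aryl group carrying an amine or a carboxylic acid.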